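A few compounds are considered here, and "the series" means these few. Any claim that something is new, unique, unknown or untested is made for them only; others in the source may bear on it.

Working notes on the series. All three measured compounds share one core and differ only in the group on an aromatic carbon of the fused system. Compound 1 `CN1CCN(c2ccc3c(c2)oc(=O)n3C(=O)NCCCCc2ccccc2)CC1=O` gives 92 nM in an assay on HEK293 cells for inhibition of acid ceramidase (Homo sapiens), read by fluorescence, with stated times of 10 min and 3 h; a lower number here means a stronger inhibitor, a higher number a weaker inhibitor. Compound 2 `CCN1CCN(c2ccc3c(c2)oc(=O)n3C(=O)NCCCCc2ccccc2)CC1` gives 56 nM in this assay, and compound 3 `CC(C)N1CCN(c2ccc3c(c2)oc(=O)n3C(=O)NCCCCc2ccccc2)CC1` gives 211 nM in this assay. Compound 3 therefore stands with the highest number of the three: a 2.3-fold higher number from compound 1 to compound 3 (0.36 log units; beyond the scatter), and a 3.8-fold higher number from compound 2 to compound 3 (0.58 log units; beyond the scatter). Between the other two, a 1.6-fold lower number from compound 1 to compound 2 (0.22 log units; within the scatter).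

Compound 4 `O=C(NCCCCc1ccccc1)n1c(=O)oc2cc(C3CCCCC3)ccc21` is not yet measured. Relative to compound 3 the change is cyclohexyl in place of 4-isopropylpiperazin-1-yl on an aromatic carbon. Within the data shown here, no measured step exchanges a nitrogen-containing ring for a carbon-only ring at this position, so nothing bears on the change directly. What does bear on it is that the three variations already seen at the same aromatic carbon moved this assay only by modest amounts, both of the steps into compound 3 being beyond the scatter but small. A step of similar, modest size is therefore expected for compound 4, with the direction uncertain; the expected step is a 1.4-fold lower number from compound 3 to compound 4 (0.15 log units; within the scatter).

Compound 4 is estimated at 150 nM in this assay, with a range from 40 nM to 600 nM.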

Compound 4, half-maximal inhibitory concentration: 89 nM
The estimate for compound 4 lay 1.7-fold (0.23 log units) above the measured number; the range from low to high includes it.
By their numbers in this assay, from the lowest: compounds 2, 4 and 1 (each within the scatter of the next); then compound 3.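

The ring nitrogens of the piperazine groups are not required for inhibition at this aromatic carbon: cyclohexyl, a six-membered non-aromatic ring of carbon only with 0 hydrogen-bond acceptors, in place of 4-isopropylpiperazin-1-yl gives a 2.4-fold lower number from compound 3 to compound 4 (0.37 log units; beyond the scatter) in this assay. Exchanging the other two nitrogen-containing groups for cyclohexyl gives a 1.6-fold higher number from compound 2 to compound 4 (0.20 log units; within the scatter) and a 1.0-fold lower number from compound 1 to compound 4 (0.01 log units; within the scatter), so a carbon-only ring sits within the scatter of both, and among the four compounds only the 4-isopropylpiperazin-1-yl group of compound 3 stands apart, with the highest number. Nothing available on these compounds accounts for why that one group differs from the others.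

The compounds shown leave open how an aromatic phenyl ring, a morpholin-4-yl ring, an open-chain amine or a carboxylic acid would behave at this aromatic carbon. Also open, from the compounds shown here alone, is whether the match between cyclohexyl and the piperazine groups holds when the 4-phenylbutyl chain on the shared core is replaced by a shorter or longer chain.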